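The source may hold more compounds than are shown below. What is called first, only, known or untested is meant among the compounds shown, and "the series" means these compounds.

Of the compounds shown here, two have been tested in a functional assay on HL-60 cells (Homo sapiens) for cytotoxicity, read by MTT assay, with a stated time of 48 h; on this read-out higher numbers stand for weaker inhibition and lower numbers for stronger inhibition. Compound 1 `Fc1cccc(-c2nc(Nc3ccccc3)c3ccccc3n2)c1` was the first of them. In this assay compound 1 gave only a limit, > 50000 nM, and no number. Compound 2 `Fc1cccc(Nc2nc(-c3cccc(F)c3)nc3ccc(F)cc23)c1` is the other. In this assay, within the data shown here, compound 2 gave 43100 nM, the only number so far among the values shown. The remaining value, that of compound 1, is a limit and sits at the limit of > 50000 nM in this assay, at which 1 of the 2 values shown sits. Among the measured compounds shown here, compound 2 thus stands alone as the one compound with a measured figure.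

The account now follows the step from compound 2 to compound 3 `Fc1cccc(-c2nc(Nc3ccccc3Cl)c3cc(F)ccc3n2)c1`. The change is 2-chlorophenyl in place of 3-fluorophenyl on a nitrogen on an aromatic ring. For the measured compounds named here, no measured step between two compounds is available to guide the expectation, so the step from compound 2 to compound 3 is expected to be a 1.1-fold lower number from compound 2 to compound 3 (0.03 log units; within the scatter), none beyond the usual scatter in either direction. Compound 3 is therefore expected to give an estimated 40000 nM in this assay, within a range from 15000 nM to 100000 nM.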

Compound 3, half-maximal inhibitory concentration: > 50000 nM
Compound 3 ended at the assay's limit; the forecaster's own chance of this, stated with the estimate: 40%; middle value at least 1.2-fold (0.09 log units) away from the limit.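

Among these compounds, the change of 3-fluorophenyl to 2-chlorophenyl on a nitrogen on an aromatic ring gives the first step that can be read, an at least 1.1-fold higher number from compound 2 to compound 3 (0.06 log units; that floor lies within the scatter). In this assay compound 3 gives > 50000 nM, which is a limit and not a number, so this step has a floor but no known size, and it shows no gain in inhibition at this position. Among the compounds shown here, with this result, the measured figure of compound 2 remains the only number, and the other values share one ceiling: the limit of > 50000 nM in this assay, at which 2 of the 3 values shown sit.

On these data alone, it remains open whether 3-chlorophenyl or 2-fluorophenyl at this position would give a number under that limit, which would separate the halogen from its place on the ring. The same holds for a methoxy group or an amine on that phenyl ring.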